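From Methoxy to Fluoro: Expecting a Small Step

This account rests on a few compounds, and the source may have more. Where it says the series, first, only, none or still open, it means among the compounds named here.

Compound 1 `COc1cc2c(cc1OC)C(=O)C(C(=O)Nc1ccccc1)C2` gives 2.2
Compound 2 `COc1ccc(NC(=O)C2Cc3cc(OC)c(OC)cc3C2=O)cc1` gives 2.08
Compound 3 `CCOc1ccc(NC(=O)C2Cc3cc(OC)c(OC)cc3C2=O)cc1` gives 2.42

These numbers come from a physicochemical assay for lipophilicity, read by mass spectrometry (a higher number here means a more lipophilic compound, a lower number a more polar compound), and in it compound 2 at 2.08 cannot be told apart from compound 1 but stands clearly short of compound 3.

Compound 4 `COc1cc2c(cc1OC)C(=O)C(C(=O)Nc1ccc(F)cc1)C2` differs from compound 2 by a single change, fluoro in place of methoxy on an aromatic carbon, para to a large group, counted as fluoro in place of methoxy on an aromatic carbon in full.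

Among the compounds with values here, three measured steps bear on this change. Methoxy in place of hydrogen gave a number 0.12 log units lower from compound 1 to compound 2 (within the scatter) and ethoxy in place of hydrogen gave a number 0.22 log units higher from compound 1 to compound 3 (within the scatter) on the same kind of carbon. Methyl added to the methoxy gave a number 0.34 log units higher from compound 2 to compound 3 (beyond the scatter) and is the only one of the three to pass the scatter.

Within the data shown here, no measured step brings in fluoro, so this remains a reasoned guess. Since compound 1 at 2.2 shows that losing the methoxy altogether changes little, compound 4 is expected to land close to it in this assay with no step beyond the scatter. The expected size is a number 0.17 log units higher from compound 2 to compound 4 (within the scatter) in this estimate. Compound 4 is estimated at 2.25 with an expected range from 1.95 to 2.55 in this assay.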

Compound 4, partition coefficient: 2.36
The estimate for compound 4 lay 0.11 log units below the measured number; the range from low to high includes it.
By their numbers in this assay, from the lowest: compounds 2, 1, 4 and 3 (each within the scatter of the next, the first and the last beyond it).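

In this assay fluoro at this place, on an aromatic carbon para to a large group, gives a number 0.28 log units higher from compound 2 to compound 4 (within the scatter) in place of methoxy and a number 0.06 log units lower from compound 3 to compound 4 (within the scatter) in place of ethoxy, while in place of hydrogen it gives a number 0.16 log units higher from compound 1 to compound 4 (within the scatter) on the same carbon. Compound 4 therefore cannot be told apart from any of the other three compounds, even though the step of a number 0.34 log units higher from compound 2 to compound 3 (beyond the scatter) still separates that one pair. Fluoro thus adds no readable step at this position, and going from 4-methoxyphenyl to 4-fluorophenyl leaves the number within the usual spread of repeated measurements, so the added methyl on the methoxy remains the only change here that passes the scatter.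

As far as these compounds go, whether a more different group at this carbon, such as an amine or a carboxylic acid, would move the number beyond the scatter stays open, as does whether a chain longer than ethoxy would carry the rise seen from methoxy to ethoxy any further. No measurement offered alongside these numbers accounts for the size of any of these steps.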